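Swapping a Saturated Ring for an Aromatic One

The source may report more compounds than this note shows. Statements on the series, on what has been measured and on what is new or still open speak of the compounds shown alone.

Of the compounds shown here, three sharing one core have been measured in a functional assay on HT-29 cells (Homo sapiens) for inhibition, read by luminescence and CellTiter-Glo, with a stated time of 24 h; on this read-out higher numbers stand for an effect only at larger amounts of compound and lower numbers for an effect already at smaller amounts. Compound 1 `CCn1nc(C(=O)N[C@H]2COc3ccccc3N(C)C2=S)nc1Cc1ccccc1` gives 17 nM. Compound 2 `CN1C(=S)[C@@H](NC(=O)c2nc(Cc3ccccc3)n(CCCCC#N)n2)COc2ccccc21` gives 2680 nM, and compound 3 `CN1C(=S)[C@@H](NC(=O)c2nc(Cc3ccccc3)n(C3CCOC3)n2)COc2ccccc21` gives 1580 nM; compound 3 therefore stands second highest of the three, close to compound 2 and far from compound 1. Compound 4 `CN1C(=S)[C@@H](NC(=O)c2nc(Cc3ccccc3)n(-c3ncccn3)n2)COc2ccccc21` differs from compound 3 in one place: pyrimidin-2-yl in place of oxolan-3-yl on an aromatic nitrogen. Two measured steps alter this same position. a 93-fold higher number from compound 1 to compound 3 (1.97 log units; beyond the scatter), while a 1.7-fold lower number from compound 2 to compound 3 (0.23 log units; within the scatter). For the measured compounds named here, both oxolan-3-yl and 4-cyanobutyl give numbers well above ethyl, but no measured step shows what an aromatic group does here. For compound 4 a number near that of compound 3 is expected, with wide uncertainty, giving a 2.3-fold lower number from compound 3 to compound 4 (0.35 log units; beyond the scatter). The estimate for compound 4 in this assay is 700 nM, within 80 nM to 6000 nM.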

Compound 4, half-maximal effective concentration: 3970 nM
Compound 4: the middle estimate sits 5.7-fold (0.75 log units) below what was measured; the range from low to high includes it.
By their numbers in this assay, from the lowest: compound 1; then compounds 3, 2 and 4 (each within the scatter of the next, the first and the last beyond it).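

An aromatic ring on this nitrogen brings no return toward compound 1: pyrimidin-2-yl gives a 2.5-fold higher number from compound 3 to compound 4 (0.40 log units; beyond the scatter), a modest step, and a 1.5-fold higher number from compound 2 to compound 4 (0.17 log units; within the scatter), which lies within the scatter. The gap to ethyl remains large, at a 230-fold higher number from compound 1 to compound 4 (2.37 log units; beyond the scatter), so a saturated ring, a nitrile-bearing chain and an aromatic ring all give numbers far above that of compound 1. Nothing available explains this result. The compounds shown leave open whether methyl keeps the low number of compound 1, and whether a plain phenyl ring behaves like pyrimidin-2-yl.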